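Amide nitrogen substituents on the shared core

A few compounds are considered here, and "the series" means these few. Any claim that something is new, unique, unknown or untested is made for them only; others in the source may bear on it.

Working notes on the series. Three compounds vary the group on one amide-type nitrogen of the shared core. In a functional assay on MIA PaCa-2 cells (Homo sapiens) for antiproliferative activity, read by MTT assay, with a stated time of 72 h (a lower number here means that less compound is needed, a higher number that more compound is needed for the effect), compound 1 `Cc1nn(Cc2cccc(C(N)=O)c2)c(C)c1NC(=O)c1ccc(COc2ccccc2)cc1` gives 9200 nM; compound 2 `CNC(=O)c1cccc(Cn2nc(C)c(NC(=O)c3ccc(COc4ccccc4)cc3)c2C)c1` gives 6200 nM; compound 3 `CCNC(=O)c1cccc(Cn2nc(C)c(NC(=O)c3ccc(COc4ccccc4)cc3)c2C)c1` gives 11000 nM, the highest of the three numbers, though every gap stays within the scatter: a 1.5-fold lower number from compound 1 to compound 2 (0.17 log units; within the scatter), a 1.2-fold higher number from compound 1 to compound 3 (0.08 log units; within the scatter), a 1.8-fold higher number from compound 2 to compound 3 (0.25 log units; within the scatter). Compound 4 `Cc1nn(Cc2cccc(C(=O)Nc3ccccc3)c2)c(C)c1NC(=O)c1ccc(COc2ccccc2)cc1` differs from compound 3 by phenyl in place of ethyl on an amide-type nitrogen. All measured steps concern the same nitrogen and none left the scatter, so no step beyond the scatter is expected in this assay from this change either, with the caveat that a phenyl is a larger change than any tested. Compound 4 is therefore estimated at 9000 nM, range 3000 nM to 27000 nM, an expected step of a 1.2-fold lower number from compound 3 to compound 4 (0.09 log units; within the scatter).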

Compound 4, half-maximal effective concentration: 6400 nM
Compound 4: middle estimate off by 1.4-fold (0.15 log units), on the high side; low and high end bracket the measured number.
By their numbers in this assay, from the lowest: compounds 2, 4, 1 and 3 (each within the scatter of the next).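

The amide-type nitrogen carries a six-membered aromatic ring without leaving the range set by hydrogen, methyl and ethyl in this assay: phenyl in place of ethyl gives a step (a 1.7-fold lower number from compound 3 to compound 4 (0.24 log units; within the scatter)), phenyl in place of methyl another (a 1.0-fold higher number from compound 2 to compound 4 (0.01 log units; within the scatter)), and phenyl in place of hydrogen a third (a 1.4-fold lower number from compound 1 to compound 4 (0.16 log units; within the scatter)). All four compounds therefore stand within the scatter of one another, despite the larger group. No supporting measurement is available to explain this result. From the compounds shown here alone, whether a longer chain, a benzyl group or a phenyl carrying an amine or carboxylic acid would produce a step beyond the scatter remains open.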